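Opening the amine of a triazolopyrimidine corticotropin-releasing factor ligand

The source may hold more compounds than are shown below. What is called first, only, known or untested is meant among the compounds shown, and "the series" means these compounds.

Measured compounds:
compound 1, `CCC(COC)N(C)c1nc(C)nc2c1nnn2-c1ccc(C(C)C)cc1Br`, 11.2 nM
compound 2, `CCCCN(CC)c1nc(C)nc2c1nnn2-c1c(Br)cc(OC)cc1OC`, 3 nM

Of the compounds shown here, two have been measured in an in vitro assay on 293-EBNA cells for binding affinity to corticotropin-releasing factor receptor 1 (Homo sapiens); a higher number here means a weaker inhibitor, a lower number a stronger inhibitor. Compound 1 gives 11.2 nM, the higher of the two numbers. Compound 2 gives 3 nM, a lower number, and the gap between them lies beyond the usual scatter. The two differ in several places at once, so only their two values can be compared.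

Compound 3, `CCC(CO)Nc1nc(C)nc2c1nnn2-c1ccc(C(C)C)cc1Br`, has not yet been measured. It is derived from compound 1 by one change: a group of 6 heavy atoms (4 carbon, 1 nitrogen, 1 oxygen; no ring) in place of a group of 8 heavy atoms (6 carbon, 1 nitrogen, 1 oxygen; no ring), on an aromatic carbon The entering (1-(hydroxymethyl)propyl)amino group carries 2 hydrogen-bond donors where the leaving group had none.

Among the measured compounds shown here, no measured pair shows a change of this kind, so the expectation rests on compound 1 alone. For compound 3 the expected step is a 1.8-fold higher number from compound 1 to compound 3 (0.25 log units; within the scatter), a modest weakening that may well stay within the scatter. Compound 3 is accordingly estimated at 20 nM, with a plausible range from 6 nM to 80 nM.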

Compound 3, inhibition constant: 25.3 nM
Compound 3: the middle estimate sits 1.3-fold (0.10 log units) below what was measured, within the range that was stated.
By their numbers in this assay, from the lowest: compound 2; then compound 1; then compound 3.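

In this assay, among the compounds shown here, the single change at this position, the (1-(hydroxymethyl)propyl)amino group in place of the larger open-chain group, gives a 2.3-fold higher number from compound 1 to compound 3 (0.35 log units; beyond the scatter). The step is modest, so this aromatic carbon of the shared core accepts an entering group that carries hydrogen-bond donors where the leaving group had none, at the cost of only a limited rise in the number. No measurement shown accounts for the step. The change removes the methyl on the amine nitrogen and the methyl of the ether together, so the compounds shown cannot assign the step to either one. From the compounds shown here alone, a methoxymethyl-bearing secondary amine or a hydroxymethyl-bearing N-methyl amine would separate the two, and a longer chain in place of the hydroxymethyl remains open as well.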